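Enantiomer step in a para-substituted carbamate series

This account rests on a few compounds, and the source may have more. Where it says the series, first, only, none or still open, it means among the compounds named here.

Measured so far:
compound 1 `C=C1C(=O)OC[C@H]1CCOC(=O)Nc1ccc(Cl)cc1` — 9140 nM
compound 2 `C=C1C(=O)OC[C@H]1CCOC(=O)Nc1ccc(I)cc1` — 12800 nM
compound 3 `C=C1C(=O)OC[C@@H]1CCOC(=O)Nc1ccccc1` — 22300 nM

In an ADME assay on RAW264.7 cells (Mus musculus) for cytotoxicity, read by MTT assay, with a stated time of 18 h (on this read-out higher numbers stand for lower toxicity in this test and lower numbers for higher toxicity in this test), compound 3 gives the highest of the three numbers, yet compound 2 lies within the scatter of it, while compound 1 lies beyond the scatter on the lower side. Among the compounds with values here, the only single-point step among the measured compounds, a 1.4-fold higher number from compound 1 to compound 2 (0.15 log units; within the scatter), concerns the halogen on the aromatic carbon and says nothing about configuration.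

Compound 4 `C=C1C(=O)OC[C@H]1CCOC(=O)Nc1ccccc1` differs from compound 3 as follows: the two compounds have the same atoms and bonds and differ only in configuration as drawn: 1 of 1 stereo elements differ; a stereocentre at a saturated ring carbon is drawn R in compound 3 and S in compound 4. Within the data shown here, no measured pair shows what such a change in configuration does on this read-out, so no step beyond the scatter is expected in this assay either way. Compound 4 is therefore estimated at 20000 nM (range 9000 nM to 45000 nM), which means an expected step of a 1.1-fold lower number from compound 3 to compound 4 (0.05 log units; within the scatter), kept flat because the number for compound 3, 22300 nM, is the only direct anchor and the other two compounds, which share the configuration drawn for compound 4, fall near it.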

Compound 4, half-maximal cytotoxic concentration: 14800 nM
For compound 4 the middle estimate is 1.4-fold (0.13 log units) above the measured one; the measured number falls inside the stated range.
By their numbers in this assay, from the lowest: compounds 1, 2, 4 and 3 (each within the scatter of the next, the first and the last beyond it).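

In this assay, within the data shown here, a 1.5-fold lower number from compound 3 to compound 4 (0.18 log units; within the scatter) gives the first direct reading of the stereocentre at the saturated ring carbon, and the two enantiomers do not separate beyond the scatter. This reading concerns configuration alone: the fact that compounds 3 and 4 differ only in the configuration as drawn. With the stereocentre drawn S, the steps on the aromatic carbon also stay within the scatter, a 1.2-fold higher number from compound 2 to compound 4 (0.06 log units; within the scatter) for hydrogen in place of iodo and a 1.6-fold higher number from compound 1 to compound 4 (0.21 log units; within the scatter) for hydrogen in place of chloro, so neither halogen separates from hydrogen on this read-out.

Among the compounds shown, chloro and iodo appear only with the stereocentre drawn S, so it remains open whether the configuration step holds with a halogen present. Also open, on these data alone, is what an amine or a carboxylic acid on the aromatic carbon would do in this assay.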